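The source may report more compounds than this note shows. Statements on the series, on what has been measured and on what is new or still open speak of the compounds shown alone.

Measured compounds:
- compound 1 `COc1ncc(-c2ccc3nc(NC(=O)NC4CC4)sc3c2)cc1NS(=O)(=O)c1ccc(F)cc1`: 900 nM
- compound 3 `CNC(=O)Nc1nc2ccc(-c3cnc(OC)c(NS(=O)(=O)c4ccc(F)cc4)c3)cc2s1`: 1560 nM
- compound 2 `CCCNc1nc2ccc(-c3cnc(Cl)c(NS(=O)(=O)c4ccc(F)cc4)c3)cc2s1`: "not determined" (no result reported)

In a functional assay on A549 cells (Homo sapiens) for antiproliferative activity, read by MTT assay, with a stated time of 72 h (on this read-out lower numbers stand for stronger inhibition and higher numbers for weaker inhibition), compound 1 gives the lowest of the two numbers, and its nearest neighbour is compound 3, where the step of a 1.7-fold higher number from compound 1 to compound 3 (0.24 log units; within the scatter) came with methyl in place of cyclopropyl on an amide-type nitrogen. Compound 4 `COc1ncc(-c2ccc3nc(NC(=O)NCCN4CCN(C)CC4)sc3c2)cc1NS(=O)(=O)c1ccc(F)cc1` differs from compound 1 at the same place: 2-(4-methylpiperazin-1-yl)ethyl in place of cyclopropyl on an amide-type nitrogen. Among the compounds with values here, no measured step covers this change; the only one at this position is the small step from compound 1 to compound 3, which suggests this nitrogen tolerates a change of group. A step in this assay of no more than the usual scatter, with a slight lean toward a higher number, is therefore expected. For compound 4 the estimate is 1300 nM, between 450 nM and 4000 nM, meaning an expected step of a 1.4-fold higher number from compound 1 to compound 4 (0.16 log units; within the scatter).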

Compound 4, half-maximal inhibitory concentration: 550 nM
Beside the measured number, compound 4's estimate is 2.4-fold (0.37 log units) above it; the range from low to high includes it.
By their numbers in this assay, from the lowest: compounds 4, 1 and 3 (each within the scatter of the next, the first and the last beyond it).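

In this assay, within the data shown here, the amide-type nitrogen carries a far larger group than the earlier compounds showed: putting 2-(4-methylpiperazin-1-yl)ethyl in place of cyclopropyl gives a 1.6-fold lower number from compound 1 to compound 4 (0.21 log units; within the scatter) and so loses nothing. Among these compounds, the other comparison gives a 2.8-fold lower number from compound 3 to compound 4 (0.45 log units; beyond the scatter) and is the first step at this position beyond the scatter, though a modest one. No measurement shown here explains these numbers.

Still open, as far as these compounds go, is whether the piperazine ring or the ethyl chain carrying it matters more; a morpholine ring or a longer chain on this nitrogen would test that.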